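The source may hold more compounds than are shown below. What is called first, only, known or untested is meant among the compounds shown, and "the series" means these compounds.

Measured so far in an ADME assay on CCRF-HSB-2 cells (Homo sapiens) for cytotoxicity, with a stated time of 7 days; on this read-out lower numbers stand for higher toxicity in this test and higher numbers for lower toxicity in this test:
- compound 1 (`Nc1nc(OCc2ccccc2)c2ncn(/C=C3/CC3(CO)CO)c2n1`) gives > 20000 nM as a limit of the assay
- compound 2 (`CCCCCCSc1nc(N)nc2c1ncn2/C=C1/CC1(CO)CO`) gives 60000 nM as a number

Within the data shown here, compound 2 at 60000 nM holds the only actual number here, which makes it the single anchor. Compound 1 sits at > 20000 nM and that is a limit, not a number. Among the measured compounds shown here, the one measured step (a step that the limit leaves unreadable from compound 1 to compound 2) therefore offers no readable size to borrow.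

Compound 3 (`CCCCCCOc1nc(N)nc2c1ncn2/C=C1/CC1(CO)CO`) differs from compound 2 in one place (hexyloxy in place of hexylsulfanyl on an aromatic carbon), with hexyloxy in place of hexylsulfanyl on an aromatic carbon. For the measured compounds named here, with the value of compound 2 (60000 nM) as the only guide, no step beyond the usual scatter is expected, and the data favour no direction. The estimated step is small (a 1.2-fold lower number from compound 2 to compound 3 (0.08 log units; within the scatter)). In this assay compound 3 is expected at 50000 nM with 20000 nM to 120000 nM as its estimated range.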

Compound 3, half-maximal cytotoxic concentration: > 20000 nM
Compound 3: no number, only a limit (the forecaster's own chance of this, stated with the estimate: 35%); the middle value does not contradict the limit.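

No new step can be read between compound 3 and either compound 1 or compound 2, because the result for compound 3 is a limit and not a number: the limit of > 20000 nM in this assay, at which 2 of the 3 values shown sit.

From the compounds shown here alone, whether benzyloxy, hexylsulfanyl or hexyloxy on the shared core gives the lowest number remains open.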